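Adding a second chloro to compound 3

The source may report more compounds than this note shows. Statements on the series, on what has been measured and on what is new or still open speak of the compounds shown alone.

Values measured in a functional assay on TSGH 8302 cells (Homo sapiens) for cytotoxicity (a higher number here means a weaker inhibitor, a lower number a stronger inhibitor), are these
- Compound 1 (`Cc1ccc(S(=O)(=O)N/C(=N\O)Nc2ccc(Cl)cc2)cc1`) gives 46 ug/mL
- Compound 2 (`Cc1c(S(=O)(=O)N/C(=N\O)Nc2ccc(Cl)c(Cl)c2)sc2ccc(Cl)cc12`) gives > 300 ug/mL
- Compound 3 (`Cc1c(S(=O)(=O)/N=C(\S)Nc2ccc(Cl)cc2)sc2ccc(Cl)cc12`) gives 55 ug/mL

Compound 3, with its 55 ug/mL in this assay as the starting point, lies within the usual scatter of compound 1 at 46 ug/mL and cannot be told apart from it. The next compound is compound 4 (`Cc1c(S(=O)(=O)/N=C(\S)Nc2ccc(Cl)c(Cl)c2)sc2ccc(Cl)cc12`), which is still to be measured. It differs from compound 3 by chloro in place of hydrogen on an aromatic carbon, ortho to a chloro group and meta to a large group, so that 4-chlorophenyl becomes 3,4-dichlorophenyl. Among the measured compounds shown here, no measured pair shows this change alone. The 3,4-dichlorophenyl group does appear in compound 2, whose > 300 ug/mL is a limit of the assay and not a number. A small move toward a higher number is therefore expected, and the estimated step of a 1.3-fold higher number from compound 3 to compound 4 (0.10 log units; within the scatter) is expected to stay within the scatter. For compound 4 the expected value is 70 ug/mL, with an estimated range from 25 ug/mL to 250 ug/mL.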

Compound 4, half-maximal inhibitory concentration: 59 ug/mL
The estimate for compound 4 lay 1.2-fold (0.07 log units) above the measured number, and the stated range covers the measured number.
By their numbers in this assay, from the lowest: compounds 1, 3 and 4 (each within the scatter of the next). At a limit, above all of these: compound 2.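

In this assay the change of chloro in place of hydrogen on an aromatic carbon, ortho to a chloro group and meta to a large group, can now be read alone, and a 1.1-fold higher number from compound 3 to compound 4 (0.03 log units; within the scatter) is what it gives. At this position on this core, 4-chlorophenyl and 3,4-dichlorophenyl therefore cannot be told apart in this assay. Compound 2 also carries 3,4-dichlorophenyl, but its value is a limit and not a number, and it sets no size for this change: the limit of > 300 ug/mL in this assay, at which 1 of the 4 values shown sits.

As far as these compounds go, whether the second chloro behaves the same way on another core remains open, as this single pair is the only one that shows it. Also open, from the compounds shown here alone, is what a methoxy group, an amine or a carboxylic acid would give at this position in this assay.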